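The source may hold more compounds than are shown below. What is called first, only, known or untested is meant among the compounds shown, and "the series" means these compounds.

Measured compounds in an assay on CHO-K1 cells for displacement of a labelled ligand from adenosine receptor A1 (Homo sapiens), read by scintillation counting, with a stated time of 60 min; on this read-out lower numbers stand for stronger inhibition and higher numbers for weaker inhibition:
- compound 1, `COc1cc(/C=N/Nc2nc(N)c3ncn([C@@H]4O[C@H](CO)[C@@H](O)[C@H]4O)c3n2)ccc1OCc1ccccc1`, gives 9140 nM.
- compound 2, `CSCC/C=N/Nc1nc(N)c2ncn([C@@H]3O[C@H](CO)[C@@H](O)[C@H]3O)c2n1`, gives only a limit of the assay, > 10000 nM.
- compound 3, `COc1cc(/C=N/Nc2nc(N)c3ncn([C@@H]4O[C@H](CO)[C@@H](O)[C@H]4O)c3n2)cc(OC)c1OC`, gives only a limit of the assay, > 10000 nM.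

Among the compounds with values here, compound 2 thus stands at the limit of this assay and not at a number; of the three values shown, two sit at that limit (the limit of > 10000 nM in this assay, at which 2 of the 3 values shown sit), and the one number, that of compound 1, is itself weak. Within the data shown here, no step between measured compounds differing in a single place is available, so no measured step size can be quoted.

Compound 4, `Nc1nc(N/N=C/c2ccc(C(F)(F)F)cc2)nc2c1ncn2[C@@H]1O[C@H](CO)[C@@H](O)[C@H]1O`, is not yet measured. It differs from compound 2 as follows: 4-(trifluoromethyl)phenyl in place of 2-(methylsulfanyl)ethyl on a carbon with a double bond to nitrogen. Compounds 1 and 3 both carry a substituted phenyl at that same carbon with a double bond to nitrogen, and show one weak number and one limit; nothing in the data points to a change beyond the scatter.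

The expectation for compound 4 in this assay is therefore a weak value of the same order as compound 1 or a limit, with the step of an at least 1.1-fold lower number from compound 2 to compound 4 (0.04 log units; that floor lies within the scatter) expected to be small or none. The estimate for compound 4 is 9000 nM, in the range 3000 nM to 30000 nM.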

Compound 4, inhibition constant: 37 nM
Compound 4: middle estimate off by 240-fold (2.39 log units), on the high side; the whole stated range lies above it.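

In this assay, the group on a carbon with a double bond to nitrogen now proves able to move the read-out strongly: 4-(trifluoromethyl)phenyl in place of 2-(methylsulfanyl)ethyl gives an at least 270-fold lower number from compound 2 to compound 4 (2.43 log units; beyond the scatter). A phenyl ring at that carbon does not by itself account for this, since compound 1, which carries a differently substituted phenyl there, gives 9140 nM, whereas compound 4 gives 37 nM. The step is a floor and not a measured size, because compound 2 stands at a limit and not at a number: the limit of > 10000 nM in this assay, at which 2 of the 4 values shown sit.

The compounds shown do not separate the contribution of the phenyl ring from that of the trifluoromethyl group, which would take an unsubstituted phenyl, or a phenyl carrying chlorine, methyl or a nitrile where the trifluoromethyl stands. Also open, as far as these compounds go, is whether a saturated ring such as cyclohexyl at the same carbon would behave like compound 4 or like compound 2, and whether the result holds at the other adenosine receptors.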